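Ring-position move of fluorine on the dienone series

The source may report more compounds than this note shows. Statements on the series, on what has been measured and on what is new or still open speak of the compounds shown alone.

Two members of the series have numbers in a functional assay on Hep cells (Homo sapiens) for cytotoxicity, read by sulforhodamine B assay, with a stated time of 48 h (a higher number here means a weaker inhibitor, a lower number a stronger inhibitor), so far. Compound 1 `CC1=C(/C=C/C(=O)/C=C/c2ccc(F)cc2)C(C)(C)CCC1` gives 55800 nM in this assay, and compound 2 `CC1=C(/C=C/C(=O)/C=C/c2ccc([N+](=O)[O-])cc2)C(C)(C)CCC1` gives 55500 nM. Compound 1 sits at one end of the two numbers shown, but the single step so far, a 1.0-fold lower number from compound 1 to compound 2 (0.00 log units; within the scatter), lies within the scatter, so the two cannot be told apart on these data. That step exchanges one aromatic substituent for another without moving it.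

Compound 3 `CC1=C(/C=C/C(=O)/C=C/c2ccccc2F)C(C)(C)CCC1` is not yet measured. Its change from compound 1 is 2-fluorophenyl in place of 4-fluorophenyl on a double-bonded chain carbon bound to a double-bonded chain carbon. Among the measured compounds shown here, no measured step moves a group around the ring, so nothing directly bears on this change; the only step available, a 1.0-fold lower number from compound 1 to compound 2 (0.00 log units; within the scatter), shows that swapping the group on the aryl ring left this assay unchanged, and that is the weak guide here. The expected step is therefore none beyond the scatter, a 1.0-fold lower number from compound 1 to compound 3 (0.01 log units; within the scatter). Compound 3 is estimated at 55000 nM in this assay, with a range from 25000 nM to 120000 nM.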

Compound 3, half-maximal inhibitory concentration: 23600 nM
The estimate for compound 3 lay 2.3-fold (0.37 log units) above the measured number; the whole stated range lies above it.
By their numbers in this assay, from the lowest: compound 3; then compounds 2 and 1 (each within the scatter of the next).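

Moving the fluorine registers in this assay: 2-fluorophenyl in place of 4-fluorophenyl on a double-bonded chain carbon bound to a double-bonded chain carbon gives a separation beyond the scatter (a 2.4-fold lower number from compound 1 to compound 3 (0.37 log units; beyond the scatter)), though a modest one that rests on this single pair. Among the compounds shown here, the earlier step (a 1.0-fold lower number from compound 1 to compound 2 (0.00 log units; within the scatter)) exchanged the aromatic substituent without moving it and gave no separation, so the placement of the fluorine on the aromatic ring is the first change to show a readable difference. The entering and leaving groups have the same atoms and the same counts of donors and acceptors, and nothing available here explains the shift.

On these data alone, it remains open whether this change in placement holds for substituents other than fluorine, including the nitro group of compound 2. As far as these compounds go, how a methoxy group, an amine or a carboxylic acid would read on the aromatic ring of the shared core also remains open, whether in the place of the fluorine in compound 3 or in that of compound 1.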